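Ring Size Change at the Benzylic Carbon and Plasma Inhibition

A few compounds are considered here, and "the series" means these few. Any claim that something is new, unique, unknown or untested is made for them only; others in the source may bear on it.

Measured compounds:
compound 1, `c1ccc(C(/N=C2\CCCCCN2)C2CC2)cc1`: 51%
compound 2, `c1ccc(C(/N=C2\CCCCCN2)C2CCCC2)cc1`: 46%

Both compounds were tested in a functional assay on the whole organism (plasma, strain Sprague-Dawley) with Rattus norvegicus as the target, with a stated time of 2 h, at a dose of 100 mg/kg by the oral route; on this read-out lower numbers stand for a weaker effect and higher numbers for a stronger effect at the one dose given. Compound 1, `c1ccc(C(/N=C2\CCCCCN2)C2CC2)cc1`, gives 51% in this assay. Compound 2, `c1ccc(C(/N=C2\CCCCCN2)C2CCCC2)cc1`, gives 46% in this assay. Within the data shown here, the one step between them, cyclopentyl in place of cyclopropyl on a saturated chain carbon bound to an aromatic carbon and a double-bonded nitrogen, moved the read-out a number 5 percentage points lower from compound 1 to compound 2 (within the scatter). Among the measured compounds shown here, compound 2 holds the lower of the two numbers, with compound 1 its only neighbour and not separated from it beyond the scatter.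

Compound 3, `c1ccc(C(/N=C2\CCCCCN2)C2CCCCC2)cc1`, has not been measured. It differs from compound 2 as follows: cyclohexyl in place of cyclopentyl on a saturated chain carbon bound to an aromatic carbon and a double-bonded nitrogen. For the measured compounds named here, the only step that bears on this change is the one from compound 1 to compound 2, which enlarged the same ring by the same place and stayed within the scatter. Compound 3 is therefore expected to change by about a number 4 percentage points lower from compound 2 to compound 3 (within the scatter), a shift not beyond the scatter. For compound 3 the estimated value in this assay is 42%, with a range from 26% to 58%.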

Compound 3, a percentage reported as inhibition, in the whole organism at one dose (the size of the read-out at that dose, not a potency): 0%
For compound 3 the middle estimate is 42 percentage points above the measured one; the measured number lies below the stated range.
By their numbers in this assay, from the lowest: compound 3; then compounds 2 and 1 (each within the scatter of the next).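

In this assay, the ring on the saturated chain carbon bound to an aromatic carbon and a double-bonded nitrogen does not respond evenly to enlargement: cyclopropyl and cyclopentyl stay within the scatter of each other, whereas cyclohexyl in place of cyclopentyl gives a number 46 percentage points lower from compound 2 to compound 3 (beyond the scatter), and cyclohexyl in place of cyclopropyl gives a number 51 percentage points lower from compound 1 to compound 3 (beyond the scatter). The earlier pair alone showed no effect of ring size beyond the scatter, but among the compounds shown that holds only as far as cyclopentyl, and the change to the six-membered ring of carbon only is enough to bring compound 3 to 0% at the one dose given. Nothing measured here accounts for this drop, and no explanation of it can be offered.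

The compounds shown leave open whether a cycloheptyl group or an open chain such as n-pentyl at this place would read like cyclopentyl or like cyclohexyl. They also leave open whether a tetrahydropyranyl ring, which carries an oxygen in a six-membered ring, would keep the read-out, and how compound 3 would read at any other dose.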